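Two chlorines on the amide phenyl of compound 2

The source may hold more compounds than are shown below. What is called first, only, known or untested is meant among the compounds shown, and "the series" means these compounds.

This account concerns a series built on a shared core, and it follows one change at the amide phenyl. Compound 2 `O=C(Nc1ccc(Cl)c(-c2nnc3c(Cl)cccn23)c1)c1ccccc1` is the parent; in a functional assay on AN3-CA cells (Homo sapiens) for antiproliferative activity, read by MTT assay, with a stated time of 72 h (on this read-out lower numbers stand for stronger inhibition and higher numbers for weaker inhibition), compound 2 gives 67600 nM, the lowest of the two numbers at hand. Compound 3 `O=C(Nc1ccc(Cl)c(-c2nnc3c(Cl)cccn23)c1)c1cccc(Cl)c1` carries one chloro group, and in this assay compound 3 gives 68400 nM; the step of a 1.0-fold higher number from compound 2 to compound 3 (0.01 log units; within the scatter) shows no effect beyond the scatter. Compound 1 `CS(=O)(=O)c1ccc(C(=O)Nc2ccc(Cl)c(-c3nnc4c(Cl)cccn34)c2)c(Cl)c1` shows only a limit, (the limit of > 100000 nM in this assay, at which 1 of the 3 values shown sits), and in this assay compound 1 gives > 100000 nM.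

Compound 4 `O=C(Nc1ccc(Cl)c(-c2nnc3c(Cl)cccn23)c1)c1ccc(Cl)cc1Cl` is not yet measured. It differs from compound 2 by 2,4-dichlorophenyl in place of phenyl on a carbonyl carbon. Among the measured compounds shown here, the only measured step that bears on this change is the one from compound 2 to compound 3, and it was within the scatter. With two chloro groups entering rather than one, the step of a 1.0-fold higher number from compound 2 to compound 4 (0.02 log units; within the scatter) is therefore expected to be small, with no direction beyond the scatter favoured. Compound 4 is accordingly estimated at 70000 nM in this assay, in a range from 30000 nM to 150000 nM.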

Compound 4, half-maximal inhibitory concentration: 84800 nM
For compound 4 the middle estimate is 1.2-fold (0.08 log units) below the measured one, and the stated range covers the measured number.
By their numbers in this assay, from the lowest: compounds 2, 3 and 4 (each within the scatter of the next). At a limit, above all of these: compound 1.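

In this assay, the second chlorine adds no effect beyond the scatter, as seen in a 1.3-fold higher number from compound 2 to compound 4 (0.10 log units; within the scatter) and in a 1.2-fold higher number from compound 3 to compound 4 (0.09 log units; within the scatter). Phenyl, 3-chlorophenyl and 2,4-dichlorophenyl on this carbonyl carbon therefore give numbers that cannot be told apart, so a change of two chloro groups at once does no more here than the single chloro group did. The step of an at least 1.1-fold lower number from compound 1 to compound 4 (0.07 log units; that floor lies within the scatter) gives only a floor and sets no order between chloro and methylsulfonyl on that aromatic carbon, since compound 1 is held at a limit: the limit of > 100000 nM in this assay, at which 1 of the 4 values shown sits.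

The compounds shown leave open whether any group on the amide phenyl can move the number beyond the scatter. An amine or a carboxylic acid on that ring, or a longer chain in place of it, would bear on this question.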